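From Methyl to Aminocarbamoyl on the Aromatic Nitrogen

The compounds below may be only part of what the source reports. "The series", "measured", "known", "first", "only" and "open" are said of these compounds alone.

Among the measured compounds shown here, compound 2 `Cn1cc(C(=O)c2ccn3c2CSC3c2cccnc2)c2ccc(-c3ccc(F)cc3)cc21` gives 7 nM in a functional assay (Oryctolagus cuniculus) for antagonist activity at platelet-activating factor receptor (Cavia porcellus) (on this read-out lower numbers stand for stronger inhibition and higher numbers for weaker inhibition), the lowest of the two numbers measured so far; compound 1 `CCNC(=O)n1cc(C(=O)c2ccn3c2CSC3c2cccnc2)c2ccc(-c3ccc(F)cc3)cc21` gives 19 nM in this assay. For the measured compounds named here, the only measured step, a 2.7-fold lower number from compound 1 to compound 2 (0.43 log units; beyond the scatter), accompanied the exchange of an ethylcarbamoyl for a methyl on the aromatic nitrogen. Compound 3 `NNC(=O)n1cc(C(=O)c2ccn3c2CSC3c2cccnc2)c2ccc(-c3ccc(F)cc3)cc21` moves the other way: aminocarbamoyl in place of methyl on an aromatic nitrogen. Since that step bears directly on this exchange, a modest rise is expected, a 2.1-fold higher number from compound 2 to compound 3 (0.33 log units; beyond the scatter). Compound 3 is therefore estimated at 15 nM in this assay, within 6 nM to 40 nM.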

Compound 3, inhibition constant: 25 nM
Beside the measured number, compound 3's estimate is 1.7-fold (0.22 log units) below it; the measured number falls inside the stated range.
By their numbers in this assay, from the lowest: compound 2; then compounds 1 and 3 (each within the scatter of the next).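

In this assay, the aminocarbamoyl group, like ethylcarbamoyl, reads weaker than methyl on this aromatic nitrogen, with a 3.6-fold higher number from compound 2 to compound 3 (0.55 log units; beyond the scatter) as the step. The end of the carbamoyl group makes no readable difference here: amino in place of ethyl gives a 1.3-fold higher number from compound 1 to compound 3 (0.12 log units; within the scatter) and stays within the scatter. Nothing available explains either step.

Open, as far as these compounds go, is how a bare hydrogen or a simple ethyl chain on this nitrogen would read. A carboxylic acid or a longer carbamoyl chain at this position also remains untested by the compounds shown here.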